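Acetyl in place of propoxycarbonyl on a thiophene dihydropyrimidinone

A few compounds are considered here, and "the series" means these few. Any claim that something is new, unique, unknown or untested is made for them only; others in the source may bear on it.

Measured compounds:
- compound 1 `CCCOC(=O)C1=C(C)NC(=O)NC1c1ccsc1`: 6%
- compound 2 `CCCOC(=O)C1=C(C)N(C)C(=O)NC1c1ccsc1`: 11%

Both measured compounds share one core. In an assay on membranes from HeLa cells for displacement of a labelled ligand from adenosine receptor A3 (Homo sapiens), read by scintillation counting, with a stated time of 180 min, tested at 1 uM (on this read-out lower numbers stand for less inhibition and higher numbers for more inhibition at the one concentration tested (going by the name of the read-out)), compound 1 gives 6%, and compound 2 gives 11%. For the measured compounds named here, compound 1 stands lowest of the two numbers, but the only step, methyl in place of hydrogen on an amide-type nitrogen in a ring, was a number 5 percentage points higher from compound 1 to compound 2 (within the scatter), so the two values cannot be told apart.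

Compound 3 `CC(=O)C1=C(C)NC(=O)NC1c1ccsc1` differs from compound 1 by methyl in place of propoxy on a carbonyl carbon. Going by the values given here, no measured step touches the carbonyl carbon, so the step from compound 1 to compound 2 bears on this change only in showing that the core gives low inhibition in this assay whatever sits on the ring nitrogen. A step no larger than the scatter is therefore expected, a number 2 percentage points higher from compound 1 to compound 3 (within the scatter). Compound 3 is expected to give 8%, estimated between -5% and 22%.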

Compound 3, a percentage reported as inhibition, at one concentration (the size of the read-out at that concentration, not a potency): 1%
Compound 3: the middle estimate sits 7 percentage points above what was measured; the range from low to high includes it.
By their numbers in this assay, from the lowest: compounds 3, 1 and 2 (each within the scatter of the next).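

In this assay the change from propoxycarbonyl to acetyl gives a number 5 percentage points lower from compound 1 to compound 3 (within the scatter) and so leaves the number where it was, within the scatter. For the compounds shown here, this is the first reading at the carbonyl carbon, as the earlier step touched only the amide-type nitrogen in a ring, and it shows that cutting propoxy down to methyl at this place does not move the read-out beyond the scatter. No evidence is available that would explain this result.

Going by these compounds, it remains open whether a different group on the carbonyl carbon, such as an amine or a longer chain ending in a carboxylic acid, would give a number clearly apart from these. On these data alone, it is also open whether methyl on the ring nitrogen would give the same small step when acetyl is present.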